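The source may report more compounds than this note shows. Statements on the series, on what has been measured and on what is new or still open speak of the compounds shown alone.

In an assay on isolated protein for activation of Nicotinamide phosphoribosyltransferase (Homo sapiens) (a higher number here means that more compound is needed for the effect, a lower number that less compound is needed), the three measured compounds stand as follows:

Compound 1, `O=C(NCc1ccncc1)Nc1ccc(S(=O)(=O)Nc2ccccc2)cc1`, gives 410 nM.
Compound 2, `CCOC(=O)c1ccc(NC(=S)NCc2ccncc2)cc1`, gives 9770 nM.
Compound 3, `O=C(NCc1ccncc1)Nc1ccc(S(=O)(=O)NCc2ccccc2)cc1`, gives 102 nM.

Compound 3 has the lowest number of the three, so the least of it is needed for activation; compound 2 sits far higher. Within the data shown here, the only single-change step recorded is a 4.0-fold lower number from compound 1 to compound 3 (0.60 log units; beyond the scatter), which concerns the same sulfonamide nitrogen. Compound 4, `CCN(CC)S(=O)(=O)c1ccc(NC(=O)NCc2ccncc2)cc1`, is compound 3 with diethylamino in place of benzylamino on a sulfonyl sulfur. Among the measured compounds shown here, no measured step tells what removing that ring does; the one recorded step only shows that a change at this position can move the number beyond the scatter. A step of a 2.5-fold higher number from compound 3 to compound 4 (0.39 log units; beyond the scatter) is therefore expected, towards a higher number. The estimate for compound 4 in this assay is 250 nM, with a range from 80 nM to 800 nM.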

Compound 4, half-maximal effective concentration: 384 nM
The estimate for compound 4 lay 1.5-fold (0.19 log units) below the measured number; the range from low to high includes it.
By their numbers in this assay, from the lowest: compound 3; then compounds 4 and 1 (each within the scatter of the next); then compound 2.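

In this assay, diethylamino in place of benzylamino on the sulfonyl sulfur gives a 3.8-fold higher number from compound 3 to compound 4 (0.58 log units; beyond the scatter), so this position keeps activity without a ring, though at a cost relative to benzylamino. Diethylamino in place of anilino gives a 1.1-fold lower number from compound 1 to compound 4 (0.03 log units; within the scatter), so here an aromatic ring alone brings no gain, and among these three groups only benzylamino stands apart. No measured evidence accounts for these differences.

From the compounds shown here alone, it remains open whether the gain with benzylamino depends on its aromatic ring or on its amino hydrogen. Cyclohexylmethylamino or morpholine at this position could help separate the two.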